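The compounds below may be only part of what the source reports. "The series", "measured", "known", "first", "only" and "open" are said of these compounds alone.

Measured in a functional assay on U-373MG ATCC cells (Homo sapiens) for inhibition, read by MTT assay, with a stated time of 72 h; on this read-out higher numbers stand for weaker inhibition and lower numbers for stronger inhibition:
- compound 1 `CC1(C)CC(NC(=S)NCc2ccccc2)c2cc(F)ccc2O1`: 27000 nM
- compound 2 `CC1(C)CC(NC(=O)Nc2cccc(Cl)c2)c2cc(Br)ccc2O1`: 69000 nM

For the measured compounds named here, compound 1, at 27000 nM, holds the lower of the two numbers so far and therefore shows the stronger inhibition. Compound 2, at 69000 nM, lies higher, and the gap between the two is beyond the usual scatter. Going by the values given here, with only two values, no trend can be read from the series.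

The next compound to be tested is compound 3 `CC1(C)CC(NC(=S)Nc2ccc(C#N)cc2)c2cc(F)ccc2O1`. It keeps the core of compound 1 and carries 4-cyanophenyl in place of benzyl on an amide-type nitrogen.

Among the compounds with values here, no measured pair isolates this change. Compound 1 differs from compound 2 in more than one place, so the value of compound 2, 69000 nM, offers no direct guide to the size or direction of the step. In this assay, no step beyond the scatter is therefore expected, with at most a slight lean towards stronger inhibition.

The estimated change is a 1.2-fold lower number from compound 1 to compound 3 (0.09 log units; within the scatter).

For compound 3 the estimated value is 22000 nM, with an expected range of 7000 nM to 70000 nM.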

Compound 3, half-maximal inhibitory concentration: 11000 nM
Estimate against measurement, compound 3: 2.0-fold (0.30 log units) above; measured number inside the range.
By their numbers in this assay, from the lowest: compound 3; then compound 1; then compound 2.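

In this assay, for the compounds shown here, compounds 1 and 3 form the first pair that differs in one place, and it shows that the group on the amide-type nitrogen bearing the thiocarbonyl carbon can shift the read-out: 4-cyanophenyl in place of benzyl gives a 2.5-fold lower number from compound 1 to compound 3 (0.39 log units; beyond the scatter), a modest step towards stronger inhibition, with compound 3 at 11000 nM. This single step bundles two differences, the arrival of the nitrile and the replacement of benzyl by a phenyl ring, and the pair does not separate them. No measured information on the origin of this step is available.

Plain phenyl and 4-cyanobenzyl on the same nitrogen would show how much of the step belongs to the nitrile and how much to the loss of benzyl, while a methoxy or a carboxylic acid in place of the nitrile would show whether the step is specific to that group. On these data alone, compound 2 differs from compound 3 in more than one place, so the effects of a carbonyl in place of the thiocarbonyl and of bromo in place of fluoro on the shared core also remain open.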